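Amide replacing urea on the shared core

The compounds below may be only part of what the source reports. "The series", "measured", "known", "first", "only" and "open" are said of these compounds alone.

Compound 2 `COc1cc(-c2nn(-c3cccc(NC(=O)Nc4cccc(C(F)(F)F)c4)c3)cc2-c2ccncc2)ccc1Cl` stands at the lowest of the two numbers shown, the gap to compound 1 being within the scatter: in a functional assay on NCI-H522 cells (Homo sapiens) for inhibition, read by sulforhodamine B assay, with a stated time of 48 h (on this read-out lower numbers stand for stronger inhibition of growth and higher numbers for weaker inhibition of growth), compound 2 gives 2430 nM. Among the measured compounds shown here, compound 1 `COc1cc(-c2nn(-c3cccc(NC(=O)c4cccc(C(F)(F)F)c4)c3)cc2-c2ccncc2)ccc1Cl` in this assay gives 3850 nM; the single measured step, a 1.6-fold lower number from compound 1 to compound 2 (0.20 log units; within the scatter), lies within the scatter. Compound 3 `COc1cc(-c2nn(-c3cccc(NC(=O)c4ccc(Cl)c(C(F)(F)F)c4)c3)cc2-c2ccncc2)ccc1Cl` differs from compound 2 in one place: 4-chloro-3-(trifluoromethyl)phenyl in place of (3-(trifluoromethyl)phenyl)amino on a carbonyl carbon. This change runs opposite to the measured step, taking the urea back to an amide, now carrying a 4-chloro-3-(trifluoromethyl)phenyl group. For the measured compounds named here, because a 1.6-fold lower number from compound 1 to compound 2 (0.20 log units; within the scatter) stayed within the scatter, only a small step, if any, is expected in this assay, leaning toward a somewhat higher number; the added chloro group has no measured counterpart here. The expected step is a 1.3-fold higher number from compound 2 to compound 3 (0.12 log units; within the scatter). Compound 3 is therefore estimated at 3200 nM, with a range from 1200 nM to 8500 nM.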

Compound 3, concentration for total growth inhibition: 13400 nM
Estimate against measurement, compound 3: 4.2-fold (0.62 log units) below, outside the stated range (above it).
By their numbers in this assay, from the lowest: compounds 2 and 1 (each within the scatter of the next); then compound 3.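

In this assay, chloro in place of hydrogen on an aromatic carbon gives a 3.5-fold higher number from compound 1 to compound 3 (0.54 log units; beyond the scatter), the single-place change in the amide pair that lies beyond the scatter. Exchange of (3-(trifluoromethyl)phenyl)amino for 4-chloro-3-(trifluoromethyl)phenyl on the carbonyl carbon gives a 5.5-fold higher number from compound 2 to compound 3 (0.74 log units; beyond the scatter), so the group on this carbonyl carbon can shift the read-out toward weaker inhibition of growth, which the earlier step between compound 1 and compound 2 did not show. Nothing available explains the size or direction of these steps.

From the compounds shown here alone, whether the chloro group gives a step of similar size on the urea of compound 2 remains open. Also open, going by these compounds, is whether fluoro, methyl or methoxy in place of that chloro on the amide of compound 3 would give a similar step.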